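The source may hold more compounds than are shown below. What is called first, only, known or untested is meant among the compounds shown, and "the series" means these compounds.

Measured so far:
Compound 1, `CCCSc1nc(N/N=C/c2ccc(Cl)cc2)c2nnn(Cc3ccccc3)c2n1`: > 64000 nM
Compound 2, `CCCSc1nc(N/N=C(\C)c2ccccc2O)c2nnn(Cc3cccc(Cl)c3)c2n1`: 13000 nM

Both compounds were tested in a functional assay on ECa-109 cells (Homo sapiens) for antiproliferative activity, read by MTT assay, with a stated time of 72 h; a lower number here means a stronger inhibitor, a higher number a weaker inhibitor. In this assay compound 1 gives > 64000 nM, and this is a limit of the assay, not a number. Compound 1 therefore stands at the limit of > 64000 nM in this assay, at which 1 of the 2 values shown sits, so where it truly lies cannot be read from the numbers shown. In this assay compound 2 gives 13000 nM, a measured number; compound 2 differs from compound 1 in more than one place, so the two values show only what each compound gives, and nothing about any single change between them.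

Compound 3, `CCCSc1nc(N/N=C/c2ccccc2F)c2nnn(Cc3ccccc3)c2n1`, has not yet been measured. It differs from compound 1 by a single change, (2-fluorophenyl in place of 4-chlorophenyl on a carbon with a double bond to nitrogen). Within the data shown here, no measured pair shows what this kind of change does, so the size of the step in this assay is uncertain; a step no larger than the usual scatter, in either direction, is what is expected. Compound 3 is expected to give about 50000 nM, within a range of 15000 nM to 150000 nM. The step this estimate means is an at least 1.2-fold lower number from compound 1 to compound 3 (0.10 log units; that floor lies within the scatter), and it is an expectation only.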

Compound 3, half-maximal inhibitory concentration: > 64000 nM
Compound 3 ended at the assay's limit (the forecaster's own chance of this, stated with the estimate: 50%); middle value at least 1.2-fold (0.10 log units) away from the limit.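

In this assay compound 3 gives > 64000 nM as a limit of the assay, not a number. Among these compounds, compound 1 sits at the same limit, so no step between compound 1 and compound 3 can be read: the limit of > 64000 nM in this assay, at which 2 of the 3 values shown sit. In this assay the compounds shown leave open what 2-fluorophenyl in place of 4-chlorophenyl does.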